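Swapping the Methoxyphenyl Arm for Pyridin-2-yl

A few compounds are considered here, and "the series" means these few. Any claim that something is new, unique, unknown or untested is made for them only; others in the source may bear on it.

Among the measured compounds shown here, compound 2 `COc1ccc(C(c2ccccc2)n2ccc3cc(/C(C)=C/C(=O)Nc4ccccc4OCCCC(=O)O)ccc32)cc1` has the lowest number so far in an assay on Prostate gland for inhibition of steroid 5-alpha-reductase (Rattus norvegicus); a higher number here means a weaker inhibitor, a lower number a stronger inhibitor: compound 2 gives 8.8 nM. For the measured compounds named here, its only close relative is compound 1 `C/C(=C\C(=O)Nc1ccccc1OCCCC(=O)O)c1ccc2c(ccn2C(C)c2ccccc2)c1`, which in this assay gives 19 nM; the step from compound 1 to compound 2 is a 2.2-fold lower number from compound 1 to compound 2 (0.33 log units; beyond the scatter), a change of 4-methoxyphenyl in place of methyl on a saturated chain carbon bound to an aromatic carbon and an aromatic nitrogen. Compound 3 `C/C(=C\C(=O)Nc1ccccc1OCCCC(=O)O)c1ccc2c(ccn2C(c2ccccc2)c2ccccn2)c1` differs from compound 2 by pyridin-2-yl in place of 4-methoxyphenyl on a saturated chain carbon bound to an aromatic carbon and an aromatic nitrogen. Going by the values given here, no measured step exchanges one aromatic ring for another at this position, so the earlier step only shows that this arm matters. Among the compounds with values here, with no direct precedent, the step from compound 2 to compound 3 is expected to be a 1.4-fold higher number from compound 2 to compound 3 (0.13 log units; within the scatter), nothing beyond the scatter. Compound 3 is therefore estimated at 12 nM in this assay, within a range of 5 nM to 30 nM.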

Compound 3, half-maximal inhibitory concentration: 37 nM
Compound 3: middle estimate off by 3.1-fold (0.49 log units), on the low side; measured number above the stated range.
By their numbers in this assay, from the lowest: compound 2; then compounds 1 and 3 (each within the scatter of the next).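

In this assay the identity of this aromatic ring clearly counts, since the exchange gives a 4.2-fold higher number from compound 2 to compound 3 (0.62 log units; beyond the scatter). The pyridin-2-yl arm also gives a 1.9-fold higher number from compound 1 to compound 3 (0.29 log units; within the scatter), so among these compounds, an aromatic ring on this saturated chain carbon does not by itself bring the gain seen with 4-methoxyphenyl. No measurement shown here accounts for the difference between these two rings.

Compound 2 and compound 3 differ in two ways at once, the methoxy group and the ring nitrogen, and the compounds shown do not separate these two changes. A plain phenyl, pyridin-3-yl or pyridin-4-yl at this carbon would show whether the methoxy group, the ring nitrogen or where that nitrogen sits governs the result.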